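Chloro for methyl on the aryl ring of compound 3

The source may report more compounds than this note shows. Statements on the series, on what has been measured and on what is new or still open speak of the compounds shown alone.

Of the compounds shown here, three sharing one core have been measured in an assay on LX2 cells for inhibition of COL1A1 promoter (Homo sapiens), read by a luciferase reporter, with a stated time of 24 h, tested at 50 uM; a lower number here means a weaker effect, a higher number a stronger effect of the compound at the concentration tested. Compound 1 `CN(C)c1ccc2c(=O)c(C(=O)Nc3cc(F)cc(F)c3)cn(-c3ccc(Cl)c(OCCCCCCC[N+]45CCN(CC4)CC5)c3)c2n1` gives 18.7%. Compound 2 `CN(C)c1ccc2c(=O)c(C(=O)Nc3cc(F)cc(F)c3)cn(-c3ccc(Cl)c(OCCCCCCC[N+]4(C)CCCCC4)c3)c2n1` gives 90.5%, and the step of a number 71.8 percentage points higher from compound 1 to compound 2 (beyond the scatter) shows how strongly the charged head group alone can move the read-out. Compound 3 `Cc1ccc(-n2cc(C(=O)Nc3cc(F)cc(F)c3)c(=O)c3ccc(N(C)C)nc32)cc1OCCCCCCC[N+](C)(C)C1CCCCC1` gives 61.7%, which places it second of the three: compound 2 stands higher, beyond the scatter, and compound 1 stands lower, beyond the scatter.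

Compound 4 `CN(C)c1ccc2c(=O)c(C(=O)Nc3cc(F)cc(F)c3)cn(-c3ccc(Cl)c(OCCCCCCC[N+](C)(C)C4CCCCC4)c3)c2n1` has not yet been measured in this assay. It differs from compound 3 in one place: chloro in place of methyl on an aromatic carbon. Among the measured compounds shown here, no measured pair shows this exchange on its own. Compound 2 carries the chloro group but with a different charged head, and compound 1 also carries it, so what is known of the chloro-bearing compounds spans a wide range in this assay. For the measured compounds named here, the one measured step, from compound 1 to compound 2, concerns the head group and not the aryl substituent, so it bears on the present change only indirectly.

On this basis compound 4 is expected to land near its methyl counterpart, with a step of about a number 8.3 percentage points higher from compound 3 to compound 4 (within the scatter), perhaps leaning upward toward the chloro-bearing compound 2. Compound 4 is therefore estimated at 70%, within a range from 45% to 92%.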

Compound 4, a percentage reported as inhibition, at one concentration (the size of the read-out at that concentration, not a potency): 81.4%
For compound 4 the middle estimate is 11.4 percentage points below the measured one; measured number inside the range.
By their numbers in this assay, from the lowest: compound 1; then compound 3; then compounds 4 and 2 (each within the scatter of the next).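

In this assay the exchange of methyl for chloro, on the aromatic carbon ortho to a large group and para to a large group, is now seen on its own with the head group held fixed, and it gives a number 19.7 percentage points higher from compound 3 to compound 4 (beyond the scatter). This shows that the aryl substituent at this position can move the read-out by itself, though by much less than the largest head group change seen among these compounds. With chloro in place, the cyclohexyl-bearing head of compound 4 and the six-membered ring head of compound 2 are not separated, as shown by a number 9.1 percentage points lower from compound 2 to compound 4 (within the scatter), while the two-ring head of compound 1 remains far apart, as shown by a number 62.7 percentage points higher from compound 1 to compound 4 (beyond the scatter), and no measurement offered here accounts for any of these steps.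

The compounds shown leave open whether the same exchange gives a similar step with the other two head groups, and whether a fluoro, a bromo or a methoxy group on this aromatic carbon would fall nearer to chloro or to methyl. They also leave open how a shorter or a longer chain between the aryl oxygen and the head group would bear on the read-out.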